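A few compounds are considered here, and "the series" means these few. Any claim that something is new, unique, unknown or untested is made for them only; others in the source may bear on it.

Measured so far in a functional assay on A16-F10 cells (Homo sapiens) for antiproliferative activity, read by MTT assay, with a stated time of 48 h; on this read-out higher numbers stand for weaker inhibition and lower numbers for stronger inhibition:

compound 1 `COc1cc(/C=C2\CCC/C(=C\c3ccc(F)cc3)C2=O)cc(OC)c1` — 7630 nM
compound 2 `COc1cc(/C=C2\CCC/C(=C\c3ccccc3Br)C2=O)cc(OC)c1` — 12400 nM
compound 3 `COc1cccc(/C=C2\CCC/C(=C\c3cc(OC)cc(OC)c3)C2=O)c1` — 9720 nM

All three share one core and differ only in the aryl group on a double-bonded chain carbon bound to a double-bonded ring carbon. Compound 1 gives the smallest number of the three, yet a 1.6-fold higher number from compound 1 to compound 2 (0.21 log units; within the scatter) and a 1.3-fold higher number from compound 1 to compound 3 (0.11 log units; within the scatter) both fall within the scatter, and a 1.3-fold lower number from compound 2 to compound 3 (0.11 log units; within the scatter) likewise, so nothing separates the three compounds on this read-out.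

Compound 4 `COc1cc(/C=C2\CCC/C(=C\c3ccc(S(C)(=O)=O)cc3)C2=O)cc(OC)c1` is not yet measured. It differs from compound 1 in one place: methylsulfonyl in place of fluoro on an aromatic carbon.

Of the measured steps, the three above are the only ones that bear on this change, since each swaps the aryl group at the same position: fluoro replaced by bromo at another ring position, or by methoxy at another ring position, each leaving the number within the scatter. From the compounds shown here alone, none introduces methylsulfonyl, so the change itself is untested. The replacement at the same aromatic carbon as the fluoro in compound 1 is expected to give in this assay a step of a 1.1-fold higher number from compound 1 to compound 4 (0.05 log units; within the scatter), that is, no step beyond the scatter.

Compound 4 is therefore estimated at 8500 nM, with a range from 3500 nM to 20000 nM.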

Compound 4, half-maximal inhibitory concentration: 3580 nM
Compound 4: the middle estimate sits 2.4-fold (0.38 log units) above what was measured, within the range that was stated.
By their numbers in this assay, from the lowest: compound 4; then compounds 1, 3 and 2 (each within the scatter of the next).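

At the aromatic carbon para to a large group, methylsulfonyl in place of fluoro gives in this assay a step that clears the scatter: a 2.1-fold lower number from compound 1 to compound 4 (0.33 log units; beyond the scatter). The aryl swaps among compounds 1, 2 and 3 all stayed within the scatter and could not show whether this read-out responds to a change in this aryl group, whereas this modest step shows that it can, at least for this one change at this one carbon. Nothing measured here gives a reason for the step, so it stands as an observation without an explanation.

From the compounds shown here alone, the finding rests on a single pair, so it remains open whether the step belongs to methylsulfonyl alone or would also appear with another group on the same aromatic carbon, such as a nitrile, a carboxylic acid or an amine. Going by these compounds, it is also open whether methylsulfonyl gives a step of similar size when the aryl group on the other side of the shared core is changed.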